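Adding a Methyl to the Six-Membered Non-Aromatic Ring

The source may report more compounds than this note shows. Statements on the series, on what has been measured and on what is new or still open speak of the compounds shown alone.

Compound 1 `Cc1sc2c(F)cccc2c1C1C=CN=CN1`: 10 mg/kg
Compound 2 `Cc1sc2ccccc2c1C1C=CN=CN1`: 3 mg/kg
Compound 3 `Cc1sc2ccc(Cl)cc2c1C1C=CN=CN1`: 3 mg/kg

All three were tested in a functional assay on the whole organism with Mus musculus as the target, with a stated time of 15 min; on this read-out higher numbers stand for an effect only at larger amounts of compound and lower numbers for an effect already at smaller amounts. Compound 2 and compound 3 share the lowest value at the digits given, and compound 1 sits higher: a 3.3-fold lower number from compound 1 to compound 2 (0.52 log units; beyond the scatter), whereas no change at the digits printed from compound 2 to compound 3 (within the scatter). Compound 4 `CC1=NC=CC(c2c(C)sc3ccccc23)N1` has not yet been measured. It differs from compound 2 by methyl in place of hydrogen on a carbon with a double bond to nitrogen. Neither measured step bears on this change: both alter a substituent on an aromatic carbon of the shared core, and the six-membered non-aromatic ring is untouched in all three. With no guidance from the data, compound 4 is expected to give about 3 mg/kg. That estimate means no change at the digits printed from compound 2 to compound 4 (within the scatter), no change beyond the scatter. The expected range for compound 4 is wide, from 1 mg/kg to 10 mg/kg.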

Compound 4, minimum effective dose: 30 mg/kg
Compound 4: the middle estimate sits 10-fold (1.00 log units) below what was measured; measured number outside the range, above it.
By their numbers in this assay, from the lowest: compounds 2 and 3 (each within the scatter of the next); then compound 1; then compound 4.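

Methyl in place of hydrogen on the carbon between two ring nitrogen atoms gives a 10-fold higher number from compound 2 to compound 4 (1.00 log units; beyond the scatter) in this assay. So this position of the six-membered non-aromatic ring, untouched in the earlier compounds, is not neutral: even this single added carbon means an effect appears only at a larger dose. The data at hand offer no measured explanation for this shift. Going by these compounds, whether the same holds for other groups remains open. An ethyl group, an amine or a chloro group at this carbon would show whether the loss is specific to methyl.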